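Plasma Protein Binding Across Azole and Azine Substituents

The compounds below may be only part of what the source reports. "The series", "measured", "known", "first", "only" and "open" are said of these compounds alone.

Compound 1 `Cc1cc(-c2ncccn2)cc(C(=O)NNS(=O)(=O)c2ccccc2)c1F`: 99.4%
Compound 2 `Cc1cc(-n2cccn2)cc(C(=O)NNS(=O)(=O)c2ccccc2)c1F`: 99.2%
Compound 3 `Cc1cc(-c2ccccn2)cc(C(=O)NNS(=O)(=O)c2ccccc2)c1F`: 99.9%

In an ADME assay on a cell-free system (plasma, Mus musculus) for protein binding, read by LC-MS, using ultracentrifugation, with a stated time of 4.2 h, tested at 1000 ng/mL, compound 3 shows the lowest unbound fraction of the three; its nearest neighbour is compound 1 a 6.0-fold lower unbound fraction from compound 1 to compound 3 (0.78 log units; beyond the scatter) and its furthest is compound 2 an 8.0-fold lower unbound fraction from compound 2 to compound 3 (0.90 log units; beyond the scatter). Compound 4 `Cc1cc(-n2nccn2)cc(C(=O)NNS(=O)(=O)c2ccccc2)c1F` differs from compound 3 by 2H-1,2,3-triazol-2-yl in place of pyridin-2-yl on an aromatic carbon. The step from compound 1 to compound 2 a 1.3-fold higher unbound fraction from compound 1 to compound 2 (0.12 log units; within the scatter) shows that two different small heteroaryl groups at this place give values within the scatter of each other, while compound 3 alone sits apart. Since the group entering compound 4 is, like that of compound 2, a five-membered azole attached through nitrogen, compound 4 is expected to move back towards compounds 1 and 2, with a step a 6.0-fold higher unbound fraction from compound 3 to compound 4 (0.78 log units; beyond the scatter) estimated to be beyond the scatter. Compound 4 is therefore estimated at 99.4%, in the range 98.8% to 99.8%.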

Compound 4, plasma protein binding in the Mus musculus assay: 99.4%
Beside the measured number, compound 4's estimate shows no gap at the digits printed; measured number inside the range.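

In the Mus musculus assay, the 2H-1,2,3-triazol-2-yl group falls in with the groups of compounds 1 and 2, with a 1.3-fold lower unbound fraction from compound 2 to compound 4 (0.12 log units; within the scatter) and no change at the digits printed from compound 1 to compound 4 (within the scatter). With a 6.0-fold higher unbound fraction from compound 3 to compound 4 (0.78 log units; beyond the scatter), pyridin-2-yl remains the only one of the four groups shown that stands apart at this position. In a physicochemical assay for solubility, read by nephelometry, in phosphate buffer, measured as kinetic solubility, at pH 6.5 (a higher number here means a more soluble compound, a lower number a less soluble compound), compound 3 gives 6.3 ug/mL and compound 4 gives 25 ug/mL. The same change also separates the two compounds in the physicochemical assay: the measured solubility of compound 3, 6.3 ug/mL, and of compound 4, 25 ug/mL, a 4.0-fold higher number (0.60 log units; beyond the scatter)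

The compounds shown leave open whether an amine or a carboxylic acid at this place would stay with compound 1, compound 2 and compound 4 in plasma protein binding. They also leave open whether solubility follows the unbound fraction beyond this single pair.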